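Adding a fluoro group to compound 1

The compounds below may be only part of what the source reports. "The series", "measured", "known", "first", "only" and "open" are said of these compounds alone.

Going by the values given here, compound 1 `O=C1c2ccc(O)c(O)c2C(=O)N1Cc1cccc(Cl)c1` gives 13300 nM in an ADME assay on HOS cells (Homo sapiens) for cytotoxicity (on this read-out lower numbers stand for stronger inhibition and higher numbers for weaker inhibition), and sits at the top of the three numbers measured so far, level with compound 2 `O=C1c2ccc(O)c(O)c2C(=O)N1Cc1cccc(Br)c1` at 11400 nM on this read-out. Compound 3 `O=C1c2ccc(O)c(O)c2C(=O)N1Cc1ccc(Cl)c(Cl)c1` lies lower at 4430 nM and marks the bottom of the set.

Compound 4 `O=C1c2ccc(O)c(O)c2C(=O)N1Cc1cccc(Cl)c1F` keeps compound 1 intact apart from one change, counted as fluoro in place of hydrogen on an aromatic carbon and described as fluoro in place of hydrogen on an aromatic carbon, ortho to a chloro group.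

Among the compounds with values here, two measured steps bear on this change. Bromo in place of chloro gives a 1.2-fold lower number from compound 1 to compound 2 (0.07 log units; within the scatter) and so offers no sign of a large move when one halogen replaces another. The closer precedent is chloro in place of hydrogen, which gives a 3.0-fold lower number from compound 1 to compound 3 (0.48 log units; beyond the scatter) as a modest step, although that chloro stands on a different carbon. Within the data shown here, no measured compound carries a fluoro group, so this guide is loose. Among the measured compounds shown here, with compound 3 as the only precedent for adding a halogen, a small move in the same direction is expected in this assay and it may not clear the scatter. The estimated step is a 1.3-fold lower number from compound 1 to compound 4 (0.12 log units; within the scatter) on this reasoning. Compound 4 is expected at 10000 nM within an estimated range of 5000 nM to 18000 nM once it is measured.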

Compound 4, half-maximal inhibitory concentration: 11500 nM
The estimate for compound 4 lay 1.2-fold (0.06 log units) below the measured number; measured number inside the range.
By their numbers in this assay, from the lowest: compound 3; then compounds 2, 4 and 1 (each within the scatter of the next).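

In this assay, fluoro in place of hydrogen on an aromatic carbon, ortho to a chloro group, gives a 1.2-fold lower number from compound 1 to compound 4 (0.06 log units; within the scatter) and so leaves compound 4 level with compound 1. Going by these compounds alone, until now, the only step that added a halogen was a 3.0-fold lower number from compound 1 to compound 3 (0.48 log units; beyond the scatter) at a different carbon, so the fluoro result adds a first reading at this position, where a single added fluorine atom ortho to a chloro group produces no step beyond the scatter. No measurement available here accounts for this outcome at this position.

Going by these compounds, a single small substituent does not define the tolerance of this carbon, so it remains open whether a methoxy group, an amine or a carboxylic acid placed here would shift the number in this assay beyond the scatter. On these data alone, it also remains open whether a fluoro group on the carbon that carries the added chloro of compound 3 would give a step of the size seen with that chloro group.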